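The source may hold more compounds than are shown below. What is called first, only, known or untested is meant among the compounds shown, and "the series" means these compounds.

Measured so far:
- compound 1, `OCCNc1nc(-c2ccccc2)nc2c1nnn2Cc1ccccc1F`, in an assay on isolated protein for binding affinity to adenosine receptor A1 (Bos taurus) (a lower number here means a stronger inhibitor, a higher number a weaker inhibitor), gives 54000000 nM
- compound 2, `OC1CCC(Nc2nc(-c3ccccc3)nc3c2nnn3Cc2ccccc2Cl)CC1`, in this assay gives 3100000 nM

Of these two numbers, compound 2 has the lower one, and the gap to compound 1 lies beyond the scatter. Compound 3, `OCCNc1nc(-c2ccccc2)nc2c1nnn2Cc1ccccc1Cl`, is not yet measured. It differs from compound 2 in one place: 2-hydroxyethyl in place of 4-hydroxycyclohexyl on a nitrogen on an aromatic ring. Compound 1 carries the same 2-hydroxyethyl group and gives 54000000 nM, so the step of a 9.7-fold higher number from compound 2 to compound 3 (0.99 log units; beyond the scatter) is expected to go toward a higher number, clearly beyond the scatter. For compound 3 the estimate is 30000000 nM, with a range from 5000000 nM to 150000000 nM.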

Compound 3, inhibition constant: 116000000 nM
For compound 3 the middle estimate is 3.9-fold (0.59 log units) below the measured one, and the stated range covers the measured number.
By their numbers in this assay, from the lowest: compound 2; then compound 1; then compound 3.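

In this assay, 2-hydroxyethyl in place of 4-hydroxycyclohexyl on the nitrogen gives a 37-fold higher number from compound 2 to compound 3 (1.57 log units; beyond the scatter), a large change with the rest of the molecule held fixed. Chloro in place of fluoro on an aromatic carbon gives a modest change, a 2.1-fold higher number from compound 1 to compound 3 (0.33 log units; beyond the scatter), so the nitrogen substituent moves the number more in these compounds. No available measurement explains either step. As far as these compounds go, whether a longer chain, or an amine in place of the hydroxyl at the chain end, would lower or raise the number remains open. So does whether the two changes would add up in a compound combining 4-hydroxycyclohexyl with fluoro.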